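Benzyl in place of methyl on the selenium of compound 1

The source may hold more compounds than are shown below. What is called first, only, known or untested is meant among the compounds shown, and "the series" means these compounds.

Measured compounds:
- compound 1 `C[Se]/C(=N\C(=O)c1ccco1)NC(=O)c1ccco1`: 40200 nM
- compound 2 `O=C(/N=C(/NC(=O)c1cccs1)[Se]Cc1ccccc1)c1cccs1`: > 100000 nM
- compound 3 `CS/C(=N\C(=O)c1cc2ccccc2s1)NC(=O)c1cc2ccccc2s1`: 5600 nM

In an ADME assay on MCF-10A cells (Homo sapiens) for cytotoxicity, read by MTT assay, with a stated time of 72 h (on this read-out higher numbers stand for weaker inhibition of growth and lower numbers for stronger inhibition of growth), compound 1 gives 40200 nM. Within the data shown here, of the two numbers known, this is the higher one, so compound 1 sits at the weaker end. Among the measured compounds shown here, compound 3, the only other compound with a number, gives 5600 nM in this assay, a gap well beyond the scatter. Compound 2, which carries the benzyl on selenium together with a different amide, returns only a limit, > 100000 nM, which means no number was reached in this assay; one of the three values shown is such a limit (the limit of > 100000 nM in this assay, at which 1 of the 3 values shown sits).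

Compound 4 `O=C(/N=C(/NC(=O)c1ccco1)[Se]Cc1ccccc1)c1ccco1` is not yet measured. It differs from compound 1 in one place: phenyl in place of hydrogen on a saturated chain carbon bound to a selenium atom. For the measured compounds named here, no pair of measured compounds differs in just this way, so the size of the step has to be judged from the whole set. The expectation for the step from compound 1 to compound 4 is a move toward weaker inhibition, a 2.0-fold higher number from compound 1 to compound 4 (0.30 log units; within the scatter), since compound 2 with the same benzyl on selenium reached only a limit, > 100000 nM. Compound 4 is therefore estimated at 80000 nM, with a likely range from 30000 nM to 250000 nM, and a real chance that this assay reports only a limit.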

Compound 4, concentration for total growth inhibition: 58000 nM
The estimate for compound 4 lay 1.4-fold (0.14 log units) above the measured number, and the stated range covers the measured number.
By their numbers in this assay, from the lowest: compound 3; then compounds 1 and 4 (each within the scatter of the next). At a limit, above all of these: compound 2.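

Methyl to benzyl on the selenium is now a measured step, and in this assay it reads a 1.4-fold higher number from compound 1 to compound 4 (0.16 log units; within the scatter). A whole phenyl added on a saturated chain carbon bound to a selenium atom therefore produces no change that can be told apart from the usual scatter, at least on the core of compound 1. Compound 2 stays a limit and gives no size for this step on its different amide: the limit of > 100000 nM in this assay, at which 1 of the 4 values shown sits.

From the compounds shown here alone, whether any other group at this position would move the number beyond the scatter remains open, for example a longer chain or a chain ending in an amine or a carboxylic acid. Going by these compounds, it is also open whether methyl to benzyl would give a similar step with other amides on the core.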